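Leaving the furan: a cyclohexyl amide in the Raji series

The source may hold more compounds than are shown below. What is called first, only, known or untested is meant among the compounds shown, and "the series" means these compounds.

Compound 3 `CN1CCN(c2ccc(Nc3nc(-c4cccc(NC(=O)c5ccco5)c4)sc3C(N)=O)cc2)CC1` stands highest of the three measured compounds in a functional assay on Raji cells (Homo sapiens) for antiproliferative activity, read by CCK-8 assay, with a stated time of 72 h, tested at 40 uM (a higher number here means more inhibition at the concentration tested (going by the name of the read-out), a lower number less inhibition), where compound 3 gives 84.3%. Compound 2 `CN1CCN(c2ccc(Nc3nc(-c4cccc(NC(=O)c5ccc(C(C)(C)C)cc5)c4)sc3C(N)=O)cc2)CC1` gives 12.1%, and compound 1 `CCOC(=O)c1sc(-c2cccc(NC(=O)[C@H]3CC[C@H](C)CC3)c2)nc1Nc1ccc(N2CCN(C)CC2)cc1` gives 26.1%. For the measured compounds named here, the single step that bears on the change is a number 72.2 percentage points higher from compound 2 to compound 3 (beyond the scatter), and it is large. Compound 4 `CN1CCN(c2ccc(Nc3nc(-c4cccc(NC(=O)[C@H]5CC[C@H](C)CC5)c4)sc3C(N)=O)cc2)CC1` differs from compound 3 by 4-methylcyclohexyl in place of furan-2-yl on a carbonyl carbon. Because the furan-2-yl group gave the large gain seen in a number 72.2 percentage points higher from compound 2 to compound 3 (beyond the scatter), its removal in compound 4 is expected to cost much of that inhibition, and the 4-methylcyclohexyl group already present in compound 1 gave 26.1%. Compound 4 is therefore estimated at 30%, between 10% and 55%, a drop of a number 54.3 percentage points lower from compound 3 to compound 4 (beyond the scatter) being expected.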

Compound 4, a percentage reported as inhibition, at one concentration (the size of the read-out at that concentration, not a potency): 22.4%
For compound 4 the middle estimate is 7.6 percentage points above the measured one; the measured number falls inside the stated range.
By their numbers in this assay, from the lowest: compound 2; then compounds 4 and 1 (each within the scatter of the next); then compound 3.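

In this assay, the change at this carbonyl carbon gives a number 61.9 percentage points lower from compound 3 to compound 4 (beyond the scatter), so the 4-methylcyclohexyl ring does not keep the inhibition seen with furan-2-yl. For the compounds shown here, with a number 10.3 percentage points higher from compound 2 to compound 4 (beyond the scatter), it stands only modestly clear of 4-(tert-butyl)phenyl, leaving furan-2-yl the only one of these three groups with high inhibition. The other carbonyl position gives a number 3.7 percentage points lower from compound 1 to compound 4 (within the scatter), so amino in place of ethoxy makes no readable difference alongside the 4-methylcyclohexyl amide. Nothing available explains these steps. Going by these compounds, whether a thiophene-2-yl group would retain the inhibition remains open, as does whether ethoxy would match amino alongside the furan-2-yl amide.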